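Three Hydroxyphenyl Compounds Without Inhibition, and a Fourth

A few compounds are considered here, and "the series" means these few. Any claim that something is new, unique, unknown or untested is made for them only; others in the source may bear on it.

Measured so far:
compound 1 `Oc1ccc(-c2cc(-c3ccccc3O)cc(-c3cccc(O)c3)n2)cc1`: 0%
compound 2 `Oc1ccc(-c2cc(-c3cccc(O)c3)cc(-c3cccc(O)c3)n2)cc1`: 0%
compound 3 `Oc1ccc(-c2cc(-c3ccccc3O)cc(-c3ccc(O)cc3)n2)cc1`: 0.4%

All three were tested in an assay on isolated protein for inhibition of DNA topoisomerase 1 (Homo sapiens), with a stated time of 30 min, tested at 100 uM; a higher number here means more inhibition at the concentration tested (going by the name of the read-out), a lower number less inhibition. In this assay compound 1 gives 0%, compound 2 gives 0% and compound 3 gives 0.4%; none of them shows inhibition worth noting.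

Compound 2 differs from compound 1 by 3-hydroxyphenyl in place of 2-hydroxyphenyl on an aromatic carbon. That move gives no change at the digits printed from compound 1 to compound 2 (within the scatter). Compound 3 differs from compound 1 by 4-hydroxyphenyl in place of 3-hydroxyphenyl on an aromatic carbon, and that move gives a number 0.4 percentage points higher from compound 1 to compound 3 (within the scatter).

The unmeasured compound 4 `Oc1ccc(-c2cc(-c3ccc(O)cc3)nc(-c3cccc(O)c3)c2)cc1` differs from compound 2 by 4-hydroxyphenyl in place of 3-hydroxyphenyl on an aromatic carbon. Going by the values given here, this is the same kind of change as the one from compound 1 to compound 3, but not the same: there it sat next to the ring nitrogen and meta to a 2-hydroxyphenyl group, here it sits opposite the ring nitrogen and meta to a 3-hydroxyphenyl group. Since the earlier move left the read-out unchanged, the expected step is no change at the digits printed from compound 2 to compound 4 (within the scatter), resting on the flat step a number 0.4 percentage points higher from compound 1 to compound 3 (within the scatter) and on compound 2 at 0%. Compound 4 is therefore expected to give about 0%.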

Compound 4, a percentage reported as inhibition, at one concentration (the size of the read-out at that concentration, not a potency): 0%
Beside the measured number, compound 4's estimate shows no gap at the digits printed, within the range that was stated.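

Set side by side, the swap of 3-hydroxyphenyl for 4-hydroxyphenyl gives the same picture on both cores in this assay: the same change on two cores in this assay, a number 0.4 percentage points higher (within the scatter) from compound 1 to compound 3 and no change at the digits printed (within the scatter) from compound 2 to compound 4, 0.4 percentage points apart, within the scatter of two such steps

The new step reads no change at the digits printed from compound 2 to compound 4 (within the scatter), and the move to 4-hydroxyphenyl in place of 2-hydroxyphenyl reads no change at the digits printed from compound 1 to compound 4 (within the scatter). Together these show only that the change carries from one core to the other without lifting the read-out, and they do not show that it would carry the same way on a compound with real inhibition, since all four numbers lie at the bottom of the scale, where a flat step says little.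

From the compounds shown here alone, what stays open is whether anything built on the shared core gives inhibition worth noting in this assay. Going by these compounds, all four compounds carry only hydroxyphenyl groups, so it remains unknown whether an amine or a carboxylic acid on those rings would change the number.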